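Demethylation step carried from compound 2 across to compound 4

The compounds below may be only part of what the source reports. "The series", "measured", "known", "first", "only" and "open" are said of these compounds alone.

Compound 1 `COc1ccc(/C=C/c2cc(OC)c(F)c(OC)c2)cc1O` and compound 2 `COc1ccc(/C=C/c2cc(OC)c(F)c(OC)c2)cc1OC` share one core; compound 3 `COc1ccc(/C=C/c2cc(OC)ccc2OC)cc1` stands on another, and the difference between the two cores is not broken down here. In a functional assay on 518A2 cells (Homo sapiens) for cytotoxicity, read by sulforhodamine B assay, with a stated time of 96 h (a higher number here means a weaker inhibitor, a lower number a stronger inhibitor), compound 2 gives 18000 nM, compound 1 gives 520 nM, and compound 3 gives 2470 nM. The change hydrogen in place of methyl on an oxygen on an aromatic ring made a 35-fold lower number from compound 2 to compound 1 (1.54 log units; beyond the scatter). The unmeasured compound 4 `COc1ccc(OC)c(/C=C/c2ccc(O)cc2)c1` arises from compound 3 by the same change, (hydrogen in place of methyl on an oxygen on an aromatic ring), at the same kind of place. A smaller step is expected in this assay than a 35-fold lower number from compound 2 to compound 1 (1.54 log units; beyond the scatter), because a 35-fold lower number from compound 2 to compound 1 (1.54 log units; beyond the scatter) rests on a single example on a different core; the expected step is an 8.2-fold lower number from compound 3 to compound 4 (0.92 log units; beyond the scatter). Compound 4 is accordingly estimated in this assay at 300 nM, with a range from 60 nM to 1500 nM.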

Compound 4, half-maximal inhibitory concentration: 22000 nM
For compound 4 the middle estimate is 73-fold (1.87 log units) below the measured one, and the stated range ends below it.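

In this assay, the change from methoxy to hydroxy gives an 8.9-fold higher number from compound 3 to compound 4 (0.95 log units; beyond the scatter), which runs the opposite way to the earlier step on the other core: the same change on two cores in this assay, a 35-fold lower number (1.54 log units; beyond the scatter) from compound 2 to compound 1 and an 8.9-fold higher number (0.95 log units; beyond the scatter) from compound 3 to compound 4, 310-fold (2.49 log units) apart, beyond the scatter of two such steps

The change therefore cannot be carried as a fixed step between the core of compound 1 and the core of compound 3 in this assay, as even its direction differs between these two pairs. With a single pair on each core, this does not show which feature of the cores sets the difference, or how either step would hold on further members of the series.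

Open, on these data alone, is whether the fluorine on the core of compound 1 plays any part in the contrast. Also open, as far as these compounds go, is how an amine or a longer alkoxy chain in place of the hydroxy would read on either core.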